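This account rests on a few compounds, and the source may have more. Where it says the series, first, only, none or still open, it means among the compounds named here.

Measured in a functional assay on MCF7 cells (Homo sapiens) for inhibition, read by MTT assay, with a stated time of 48 h; on this read-out higher numbers stand for weaker inhibition and lower numbers for stronger inhibition:
- compound 1 `N#Cc1ccc2[nH]cc(C(c3ccc(Br)cc3)c3c[nH]c4ccc(C#N)cc34)c2c1`: 27100 nM
- compound 2 `N#Cc1ccc2[nH]cc(C(c3ccc([N+](=O)[O-])cc3)c3c[nH]c4ccc(C#N)cc34)c2c1`: 23600 nM

On these numbers, compound 2, at 23600 nM, cannot be told apart from compound 1. Compound 3 `CCCCCCCC(c1c[nH]c2ccc(C#N)cc12)c1c[nH]c2ccc(C#N)cc12` brings a larger structural change: heptyl in place of 4-nitrophenyl on a saturated chain carbon bound to two aromatic carbons. Within the data shown here, the only measured step is a 1.1-fold lower number from compound 1 to compound 2 (0.06 log units; within the scatter), which swapped one group on the aromatic ring and left the ring in place. Among the measured compounds shown here, no measured compound shows that ring being lost, so this is weak guidance. With that caution, no shift beyond the scatter is expected in this assay, and the expected change is a 1.2-fold lower number from compound 2 to compound 3 (0.07 log units; within the scatter). The estimated value for compound 3 is 20000 nM, with an expected range of 8000 nM to 45000 nM.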

Compound 3, half-maximal inhibitory concentration: 2500 nM
Compound 3: the middle estimate sits 8.0-fold (0.90 log units) above what was measured; measured number below the stated range.
By their numbers in this assay, from the lowest: compound 3; then compounds 2 and 1 (each within the scatter of the next).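

Heptyl in place of 4-nitrophenyl gives a 9.4-fold lower number from compound 2 to compound 3 (0.97 log units; beyond the scatter) in this assay and heptyl in place of 4-bromophenyl gives an 11-fold lower number from compound 1 to compound 3 (1.04 log units; beyond the scatter) at this saturated chain carbon bound to two aromatic carbons. So an aromatic ring at this place is not required for inhibition here, and replacing the whole group moves the number where changing only the group on the ring did not. Nothing available explains this shift. From the compounds shown here alone, whether a shorter or longer chain would go further remains open, as does the effect of an amine or a carboxylic acid at the chain end.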